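A few compounds are considered here, and "the series" means these few. Any claim that something is new, unique, unknown or untested is made for them only; others in the source may bear on it.

Compound 1 `Cc1nc(-c2cccnc2)sc1-c1nnc(Cc2ccccc2)o1`: > 100 ug/mL, a limit
Compound 2 `COc1ccccc1-c1nnc(-c2sc(-c3cccnc3)nc2C)o1`: > 100 ug/mL, a limit

In an ADME assay on THP-1 cells (Homo sapiens) for cytotoxicity, read by MTT assay (on this read-out lower numbers stand for higher toxicity in this test and higher numbers for lower toxicity in this test), compound 2 gives > 100 ug/mL, which is a limit of the assay and not a number. Compound 1 gives > 100 ug/mL, and this too is only a limit. Among the measured compounds shown here, compound 2 therefore has no exact value to stand on, and the one comparison available is the limit of > 100 ug/mL in this assay, at which 2 of the 2 values shown sit.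

Compound 3 `Cc1nc(-c2cccnc2)sc1-c1nnc(-c2ccccc2[N+](=O)[O-])o1` keeps the core of compound 2 and carries nitro in place of methoxy on an aromatic carbon. For the measured compounds named here, no measured step covers this exchange. Going by the values given here, the only step at hand is a step that the two limits leave unreadable from compound 1 to compound 2, a replacement made elsewhere in the structure, and it gives no size to carry over.

Among the compounds with values here, with no measured size to go on, no particular step or direction can be expected from the data in this assay, and compound 3 is most likely to be reported at the same limit. The expected step is a number no higher from compound 2 to compound 3 (the limit leaves the size open). For compound 3 the estimated value is 100 ug/mL, with an expected range from 35 ug/mL to 200 ug/mL.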

Compound 3, half-maximal cytotoxic concentration: > 100 ug/mL
Compound 3 ended at the assay's limit; the forecaster's own chance of this, stated with the estimate: 70%; the middle value sits exactly at the limit.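

In this assay compound 3 gives > 100 ug/mL, which is a limit and not a number. No step can be read from compound 2 to compound 3, because all the compounds shown stand at one limit: the limit of > 100 ug/mL in this assay, at which 3 of the 3 values shown sit.

The compounds shown leave open how far any of them lies beyond that limit, and whether nitro and methoxy differ at all on this read-out.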